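Sulfonyl-side swap on a urea-linked nicotinamide phosphoribosyltransferase inhibitor

The source may report more compounds than this note shows. Statements on the series, on what has been measured and on what is new or still open speak of the compounds shown alone.

Measured compounds:
compound 1 `Cc1ncccc1CNC(=O)Nc1ccc(S(=O)(=O)c2ccccc2)cc1`, 146 nM
compound 2 `O=C(NCc1ccc(Cl)nc1)Nc1ccc(S(=O)(=O)c2ccccc2)cc1`, 13 nM
compound 3 `O=C(NCc1cccnc1)Nc1ccc(S(=O)(=O)N2CC3(COC3)C2)cc1`, 103 nM

Of the compounds shown here, three share a urea-linked core and have been tested in an assay on isolated protein for inhibition of Nicotinamide phosphoribosyltransferase (Homo sapiens), read by spectrophotometry, with stated times of 15 min and 30 min; on this read-out lower numbers stand for stronger inhibition and higher numbers for weaker inhibition. Compound 1 gives 146 nM, compound 2 gives 13 nM and compound 3 gives 103 nM. Compound 3 and compound 1 sit within the scatter of each other, while compound 2 shows a clearly lower number than either. Within the data shown here, the only single-point step among them, an 11-fold lower number from compound 1 to compound 2 (1.05 log units; beyond the scatter), concerns the pyridyl substituent and not the sulfonyl side.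

Compound 4 `O=C(NCc1cccnc1)Nc1ccc(S(=O)(=O)N[C@H]2CC[C@H](O)CC2)cc1` differs from compound 3 by a group of 8 heavy atoms (6 carbon, 1 nitrogen, 1 oxygen; one six-membered non-aromatic ring of carbon only) in place of a group of 7 heavy atoms (5 carbon, 1 nitrogen, 1 oxygen; 2 four-membered non-aromatic rings with 1 hetero atom each), on a sulfonyl sulfur. Among the measured compounds shown here, no measured step touches this position, so nothing here indicates a change beyond the scatter in this assay. Compound 4 is therefore estimated at 100 nM, with a range of 30 nM to 330 nM, which is expected to correspond to a 1.0-fold lower number from compound 3 to compound 4 (0.01 log units; within the scatter).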

Compound 4, half-maximal inhibitory concentration: 8 nM
Compound 4: middle estimate off by 13-fold (1.10 log units), on the high side; the measured number lies below the stated range.
By their numbers in this assay, from the lowest: compounds 4 and 2 (each within the scatter of the next); then compounds 3 and 1 (each within the scatter of the next).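

In this assay there is a 13-fold lower number from compound 3 to compound 4 (1.11 log units; beyond the scatter) when (4-hydroxycyclohexyl)amino takes the place of the group with two four-membered rings on the sulfonyl sulfur. Among these compounds, until now the only step that could be read lay on the pyridyl substituent, so this is the first sign that the group on the sulfonyl sulfur also moves the number, although this single pair swaps 0 hydrogen-bond donors for 2 and adds 2 defined stereocentres, and it cannot show which feature matters. Nothing available explains the step. The compounds shown leave open whether the hydroxyl itself counts, which a plain cyclohexylamino group or a 4-aminocyclohexylamino group on the sulfonyl sulfur would test. They also leave open whether the other stereoisomer behaves alike, and whether the change carries over to compounds with 6-chloropyridin-3-yl.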